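From 4-methylphenyl to 3-methylphenyl in a growth inhibition series

The source may hold more compounds than are shown below. What is called first, only, known or untested is meant among the compounds shown, and "the series" means these compounds.

Compound 1 `COc1ccc(CNc2nc(Nc3ccc(N4CCN(C)CC4)cn3)ncc2Cl)cc1`: 14900 nM
Compound 2 `COc1cccc(CNc2nc(Nc3ccc(N4CCN(C)CC4)cn3)ncc2Cl)c1`: 20300 nM
Compound 3 `Cc1ccc(Nc2nc(Nc3ccc(N4CCN(C)CC4)cn3)ncc2Cl)cc1`: 4030 nM

In a functional assay on MDA-MB-231 cells (Homo sapiens) for inhibition, read by CCK-8 assay, with a stated time of 48 h (a higher number here means a weaker inhibitor of growth, a lower number a stronger inhibitor of growth), compound 3 gives the lowest of the three numbers, 4030 nM. It is separated from the other two by steps beyond the scatter: a 3.7-fold lower number from compound 1 to compound 3 (0.57 log units; beyond the scatter) and a 5.0-fold lower number from compound 2 to compound 3 (0.70 log units; beyond the scatter). Compound 4 `Cc1cccc(Nc2nc(Nc3ccc(N4CCN(C)CC4)cn3)ncc2Cl)c1` has 3-methylphenyl in place of 4-methylphenyl on a nitrogen on an aromatic ring. The closest measured parallel is the swap of 4-methoxyphenyl for 3-methoxyphenyl, a 1.4-fold higher number from compound 1 to compound 2 (0.13 log units; within the scatter), which stays within the scatter. That parallel is indirect, since those compounds carry a different group. No step beyond the scatter is therefore expected in this assay. The expected step is a 1.1-fold higher number from compound 3 to compound 4 (0.05 log units; within the scatter). Compound 4 is estimated at 4500 nM, within a range of 2000 nM to 10000 nM.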

Compound 4, concentration for 50% growth inhibition: 5270 nM
Compound 4: middle estimate off by 1.2-fold (0.07 log units), on the low side; measured number inside the range.
By their numbers in this assay, from the lowest: compounds 3 and 4 (each within the scatter of the next); then compounds 1 and 2 (each within the scatter of the next).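

In this assay, exchanging 4-methylphenyl for 3-methylphenyl on this nitrogen gives a 1.3-fold higher number from compound 3 to compound 4 (0.12 log units; within the scatter), so this position tolerates the change without a step beyond the scatter. Compound 4 also stands apart from the methoxybenzyl compounds, with a 3.9-fold lower number from compound 2 to compound 4 (0.59 log units; beyond the scatter) and a 2.8-fold lower number from compound 1 to compound 4 (0.45 log units; beyond the scatter), so that separation is not confined to the 4-methylphenyl compound. No evidence on why these compounds differ is available here. The compounds shown leave open how an amine or a carboxylic acid in place of the methyl group would read in this assay and whether a longer chain would keep compound 4's level.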